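Furan-3-yl in place of dimethylaminophenyl: cytotoxicity outlook

The source may hold more compounds than are shown below. What is called first, only, known or untested is meant among the compounds shown, and "the series" means these compounds.

The measured compounds are two. Compound 1 `O=C(NC(=S)N1CCc2c(OCCCCCOc3ccc(Cl)cc3)cccc21)c1ccc(Br)cc1`: in an ADME assay on Huh-7 cells (Homo sapiens) for cytotoxicity (on this read-out lower numbers stand for higher toxicity in this test and higher numbers for lower toxicity in this test), compound 1 gives 29100 nM. Compound 2 `CN(C)c1ccc(C(=O)NC(=S)N2CCc3c(OCCCCCOc4ccc(Cl)cc4)cccc32)cc1`: in this assay compound 2 gives only a limit, > 50000 nM.

Compound 2 thus stands at the edge of the measured range; the reading is the limit of > 50000 nM in this assay, at which 1 of the 2 values shown sits, so no number is known for it. For the measured compounds named here, the only measured step, an at least 1.7-fold higher number from compound 1 to compound 2 (0.23 log units; that floor lies within the scatter), concerns dimethylamino in place of bromo on an aromatic carbon, and its floor lies within the scatter. Compound 3 `O=C(NC(=S)N1CCc2c(OCCCCCOc3ccc(Cl)cc3)cccc21)c1ccoc1` differs from compound 2 in another place: furan-3-yl in place of 4-(dimethylamino)phenyl on a carbonyl carbon. Going by the values given here, no measured step covers an exchange on this carbonyl carbon, and the one step that exists does not share the change, so it offers no direction. The numbers shown give no sign of a sizeable move in either direction. Compound 3 is therefore estimated at 40000 nM, with a range from 15000 nM to 100000 nM. The expected step of an at least 1.2-fold lower number from compound 2 to compound 3 (0.09 log units; that floor lies within the scatter) is none beyond the scatter, and a further limit reading remains quite possible.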

Compound 3, half-maximal cytotoxic concentration: 20100 nM
Compound 3: the middle estimate sits 2.0-fold (0.30 log units) above what was measured; low and high end bracket the measured number.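

In this assay, the carbonyl carbon proves to be a place where the exchange can shift the read-out: furan-3-yl in place of 4-(dimethylamino)phenyl gives an at least 2.4-fold lower number from compound 2 to compound 3 (0.39 log units; beyond the scatter). On the same carbon, furan-3-yl in place of 4-bromophenyl gives a 1.4-fold lower number from compound 1 to compound 3 (0.16 log units; within the scatter), so the result of bringing in furan-3-yl differs with the group that leaves, and only the departure of 4-(dimethylamino)phenyl produces a step beyond the scatter. Compound 2 has only a limit, so the step from it has a floor and no known size: the limit of > 50000 nM in this assay, at which 1 of the 3 values shown sits.

As far as these compounds go, it remains open whether the dimethylamino group or the ring that carries it sets compound 2 apart, and a plain phenyl or a morpholine in place of dimethylamino on that ring would bear on this question. The shared core and its chain are the same in all three compounds, so nothing here shows how the read-out would respond to a shorter chain or to a carboxylic acid at the end of it.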